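Allyl to Ethyl: A Small Change Repeated on a Second Core

This account rests on a few compounds, and the source may have more. Where it says the series, first, only, none or still open, it means among the compounds named here.

Of the compounds shown here, three sharing one core have been measured in an assay on isolated protein for inhibition of leukotriene B4 receptor 1 (Homo sapiens), tested at 10 uM; on this read-out higher numbers stand for more inhibition at the one concentration tested (going by the name of the read-out) and lower numbers for less inhibition. Compound 1 `C=CCc1cc(C(C)=O)c(O)cc1OCc1cccc(C#N)c1` gives 71% in this assay. Compound 3 `CCc1cc(C(C)=O)c(O)cc1OCc1cccc(C#N)c1` differs from compound 1 by methyl in place of vinyl on a saturated chain carbon bound to an aromatic carbon and in this assay compound 3 gives 58%, so that the step of a number 13 percentage points lower from compound 1 to compound 3 (beyond the scatter). Compound 2 `C=CCc1cc(C(C)=O)c(O)cc1OCc1ccc(C#N)cc1` is built from the same atoms as compound 1, joined differently; how the two cores differ is not broken down here. In this assay compound 2 gives 22%, the lowest of the three numbers.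

Compound 4 `CCc1cc(C(C)=O)c(O)cc1OCc1ccc(C#N)cc1` has not yet been measured. It stands to compound 2 as compound 3 stands to compound 1: the difference is methyl in place of vinyl on a saturated chain carbon bound to an aromatic carbon, the same change made at the same place. Because the earlier step of a number 13 percentage points lower from compound 1 to compound 3 (beyond the scatter) was modest yet beyond the scatter, the same change is expected to lower the number of compound 2 by a comparable amount, although compound 2 starts low and the read-out cannot fall far. The step from compound 2 to compound 4 is expected to be a number 10 percentage points lower from compound 2 to compound 4 (within the scatter). Compound 4 is therefore estimated to give 12% in this assay, with a likely range from 0% to 30%. Going by these compounds, this expectation rests on a single earlier pair; whether the change behaves alike on the core of compound 2 remains untested.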

Compound 4, a percentage reported as inhibition, at one concentration (the size of the read-out at that concentration, not a potency): 7%
Compound 4: the middle estimate sits 5 percentage points above what was measured; low and high end bracket the measured number.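

In this assay, the change from allyl to ethyl again lowers the number on the second core, a number 15 percentage points lower from compound 2 to compound 4 (beyond the scatter). Set beside the earlier step, the change carries over from one core to the other with much the same size: the same change on two cores in this assay, a number 13 percentage points lower (beyond the scatter) from compound 1 to compound 3 and a number 15 percentage points lower (beyond the scatter) from compound 2 to compound 4, 2 percentage points apart, within the scatter of two such steps This shows that, within these four compounds, the two cores respond alike to this one change, but two pairs are too few to set a rule for other cores, and they do not explain why the number falls; moreover, each number is an inhibition read at a single concentration, so similar steps here need not mean similar changes in potency.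

The compounds shown carry only allyl or ethyl at this place, which leaves open what a longer chain such as butyl, or a chain ending in an amine or a carboxylic acid, would do to the number on either core. Going by these compounds, it is also open whether the much higher numbers of the core of compound 1 would persist if its nitrile were replaced by an amide or a carboxylic acid.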